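Imidazolyl tail on the dipalmitoyl-cysteinyl core

The source may report more compounds than this note shows. Statements on the series, on what has been measured and on what is new or still open speak of the compounds shown alone.

The measured compounds are:
- compound 1 `CCCCCCCCCCCC(=O)OC[C@H](CSC[C@@H](N)C(=O)NCCCCCCO)OC(=O)CCCCCCCCCCC`, in an assay on HEK293 cells for agonist activity at Toll-like receptor 2 (Homo sapiens) (on this read-out higher numbers stand for an effect only at larger amounts of compound and lower numbers for an effect already at smaller amounts), compound 1 gives 33 nM
- compound 2 `CCCCCCCCCCCC(=O)OC[C@H](CSC[C@@H](N)C(=O)NCCCS(=O)(=O)O)OC(=O)CCCCCCCCCCC`, compound 2 gives 5560 nM
- compound 3 `CCCCCCCCCCCC(=O)OC[C@H](CSC[C@@H](N)C(=O)NCCCCN)OC(=O)CCCCCCCCCCC`, compound 3 gives 1040 nM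

Compound 1 holds the lowest number of the three. Compound 3 is the nearest to it, and compound 2 is the furthest away. Compound 4 `CCCCCCCCCCCC(=O)OC[C@H](CSC[C@@H](N)C(=O)NCCCn1ccnc1)OC(=O)CCCCCCCCCCC` is not yet measured. It differs from compound 1 as follows: 1H-imidazol-1-yl in place of 3-hydroxypropyl on a saturated chain carbon, three bonds along the chain from an amide-type nitrogen.

Within the data shown here, two measured steps bear on this change, since each also replaces the same tail of compound 1 at the same place with another group: a 170-fold higher number from compound 1 to compound 2 (2.23 log units; beyond the scatter) and a 32-fold higher number from compound 1 to compound 3 (1.50 log units; beyond the scatter). Both steps are large and both go toward higher numbers. Compound 4 again exchanges that tail, this time for a group with no hydrogen-bond donor, so a rise is expected, though its size is uncertain. In this assay compound 4 is therefore estimated at 300 nM, with a range from 60 nM to 1500 nM. That estimate means a step of a 9.1-fold higher number from compound 1 to compound 4 (0.96 log units; beyond the scatter).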

Compound 4, half-maximal effective concentration: 410 nM
Compound 4: the middle estimate sits 1.4-fold (0.14 log units) below what was measured, and the stated range covers the measured number.
By their numbers in this assay, from the lowest: compound 1; then compound 4; then compound 3; then compound 2.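

In this assay, the 1H-imidazol-1-yl tail is a third replacement for the 3-hydroxypropyl part of the tail of compound 1, and it too raises the number (a 12-fold higher number from compound 1 to compound 4 (1.09 log units; beyond the scatter)), so none of the three replacements matches compound 1. The replacements are nevertheless not equal at this place: the ring-bearing tail gives a lower number than the other two (a 2.5-fold lower number from compound 3 to compound 4 (0.40 log units; beyond the scatter); a 14-fold lower number from compound 2 to compound 4 (1.13 log units; beyond the scatter)), which shows that the size of the rise depends on the group that enters. Nothing available explains this order.

The compounds shown leave open whether the low number of compound 1 depends on its terminal hydroxyl or on its chain length. A hydroxyl on a shorter chain, or a phenyl ring or 1H-imidazol-1-yl on a longer chain, would bear on that question.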